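The source may hold more compounds than are shown below. What is called first, only, known or untested is meant among the compounds shown, and "the series" means these compounds.

Measured compounds:
- compound 1 `C#Cc1cn([C@@H]2O[C@H](CO)[C@@H](O)[C@H]2O)c2ncnc(C)c12` gives 50 nM in an ADME assay on BJ cells (Homo sapiens), read by MTT assay, with a stated time of 72 h; a lower number here means a stronger inhibitor, a higher number a weaker inhibitor
- compound 2 `COc1ncnc2c1c(-c1ccoc1)cn2[C@@H]1O[C@H](CO)[C@@H](O)[C@H]1O` gives 28800 nM in this assay
- compound 3 `C#Cc1cn([C@@H]2O[C@H](CO)[C@@H](O)[C@H]2O)c2ncnc(NC)c12` gives 86000 nM in this assay

Compound 3 stands highest of the three numbers in this assay; its nearest neighbour is compound 2, its furthest compound 1. Within the data shown here, the one measured step that touches compound 3 is a 1700-fold higher number from compound 1 to compound 3 (3.24 log units; beyond the scatter), which shows how much the methylamino group on that aromatic carbon costs relative to methyl on the shared core.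

Compound 4 `C#Cc1cn([C@@H]2O[C@H](CO)[C@@H](O)[C@H]2O)c2ncnc(OC)c12` is the methoxy analogue of compound 3: methoxy in place of methylamino on an aromatic carbon. Among the measured compounds shown here, no measured step covers methylamino against methoxy directly. Compound 2 carries a methoxy at the same place on a differently substituted core, and its value in this assay sits not far from compound 3, while compound 1 shows that this position tolerates a small group without heteroatom. Taken together, the expectation for compound 4 in this assay is a lower number than compound 3, but well short of compound 1, so a moderate step of an 11-fold lower number from compound 3 to compound 4 (1.03 log units; beyond the scatter) is expected, with wide uncertainty. Compound 4 is therefore estimated at 8000 nM, with a range from 800 nM to 60000 nM.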

Compound 4, half-maximal inhibitory concentration: 98400 nM
Estimate against measurement, compound 4: 12-fold (1.09 log units) below, and the stated range ends below it.
By their numbers in this assay, from the lowest: compound 1; then compound 2; then compounds 3 and 4 (each within the scatter of the next).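

In this assay the step of a 1.1-fold higher number from compound 3 to compound 4 (0.06 log units; within the scatter) lies within the scatter, so methylamino and methoxy cannot be told apart at this position on the shared core, and the hydrogen-bond donor carried by methylamino but not by methoxy leaves no readable trace. The step of a 2000-fold higher number from compound 1 to compound 4 (3.29 log units; beyond the scatter) stands at a size close to that of a 1700-fold higher number from compound 1 to compound 3 (3.24 log units; beyond the scatter) and is large in the same direction, so the loss against methyl is not peculiar to methylamino but appears with both groups shown here. With methoxy held in place, the step of a 3.4-fold higher number from compound 2 to compound 4 (0.53 log units; beyond the scatter) for ethynyl in place of furan-3-yl is only modest and far smaller than either step away from methyl, so among these compounds the group at this position moves the number much further than the other substituent does.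

Nothing shown explains why methyl stands so far from methylamino and methoxy. Going by these compounds, whether the low number belongs to methyl alone remains open, and an ethyl chain, a primary amine or a chlorine at this position, on the same core, would show how narrow that preference is.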